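Boc to isopropyl carbamate on the piperidine of compound 1

This account rests on a few compounds, and the source may have more. Where it says the series, first, only, none or still open, it means among the compounds named here.

Measured so far in a functional assay on cells for agonist activity at Glucose-dependent insulinotropic receptor (Homo sapiens), read by a luciferase reporter, with a stated time of 6 h; a lower number here means that less compound is needed, a higher number that more compound is needed for the effect:
- compound 1 `CON(C)C(=O)c1ccc(-c2ccc(OCC3CCN(C(=O)OC(C)(C)C)CC3)cn2)cc1`: 171 nM
- compound 3 `CON(C)C(=O)c1ccc(-c2ccc(OCC3CCN(C(=O)OC(C)(C)C)CC3)cn2)cc1F`: 73 nM
- compound 2 `CC(C)(C)OC(=O)N1CCC(COc2ccc(-c3ccc(C(=O)NOCc4ccccc4)cc3)nc2)CC1`: "not determined" (no result reported)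

Compound 1 holds the highest of the two numbers available; its nearest neighbour is compound 3, reached by a 2.3-fold lower number from compound 1 to compound 3 (0.37 log units; beyond the scatter), a fluoro in place of hydrogen on an aromatic carbon. For compound 2 no result was reported, so it adds nothing to the comparison.

Compound 4 `CON(C)C(=O)c1ccc(-c2ccc(OCC3CCN(C(=O)OC(C)C)CC3)cn2)cc1` differs from compound 1 by hydrogen in place of methyl on a saturated chain carbon bound to an oxygen next to a carbonyl group and two saturated chain carbons; read one bond further out, this is tert-butoxycarbonyl to isopropoxycarbonyl. Going by the values given here, no measured step touches the carbamate, so the only step available, from compound 1 to compound 3, concerns a different part of the molecule and gives no direct guide. With nothing to suggest a large shift either way, the expected step is a 1.3-fold higher number from compound 1 to compound 4 (0.11 log units; within the scatter), i.e. at most a modest change, and the number for compound 4 in this assay is estimated at 220 nM, within 80 nM to 600 nM.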

Compound 4, half-maximal effective concentration: 155 nM
The estimate for compound 4 lay 1.4-fold (0.15 log units) above the measured number, within the range that was stated.
By their numbers in this assay, from the lowest: compound 3; then compounds 4 and 1 (each within the scatter of the next).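

In this assay, tert-butyl to isopropyl in the carbamate gives a 1.1-fold lower number from compound 1 to compound 4 (0.04 log units; within the scatter), so removing one methyl at this position, which the earlier fluoro step did not touch, produces no change that can be told from the scatter. Going by these compounds alone, this single pair shows that the full tert-butyl group is not required to keep the number of compound 1, whereas the aromatic change, a 2.3-fold lower number from compound 1 to compound 3 (0.37 log units; beyond the scatter), remains the only step beyond the scatter. Nothing available explains this result at the level of mechanism.

Still open is how far the group can be altered: the compounds shown do not cover an ethyl or methyl carbamate, a cyclopropyl carbamate, or a urea in its place. Also open, from the compounds shown here alone, is whether isopropyl and the fluoro of compound 3 combine additively in one molecule.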